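Swapping chloro for ethoxy on a fused purine-like core

The source may report more compounds than this note shows. Statements on the series, on what has been measured and on what is new or still open speak of the compounds shown alone.

Compound 1 `CN(c1ncnc2c1ncn2C1CC1)C1CC1` gives 4.5 mg/kg in a functional assay on the whole organism for antagonist activity, with Rattus norvegicus as the target; on this read-out lower numbers stand for an effect already at smaller amounts and higher numbers for an effect only at larger amounts of compound.
Compound 2 `Clc1nc(NC2CC2)c2ncn(CC3CC3)c2n1` gives 2.5 mg/kg in this assay.

Within the data shown here, only two compounds have been measured so far, and they share a fused two-ring core. Compound 2 has the lower of the two numbers in this assay, but its gap to compound 1 lies within the usual scatter of repeated measurements, so the two cannot be told apart on this evidence.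

The next compound, compound 3 `CCOc1nc(NC2CC2)c2ncn(CC3CC3)c2n1`, keeps everything of compound 2 except one group: ethoxy in place of chloro on an aromatic carbon between two ring nitrogen atoms. Among the measured compounds shown here, no measured pair shows what such an exchange does here, so the direction of the step is open; a small step, not beyond the scatter, is the plainest expectation. Compound 3 is therefore estimated at 3.5 mg/kg, with a range from 1 mg/kg to 12 mg/kg, which means an expected step of a 1.4-fold higher number from compound 2 to compound 3 (0.15 log units; within the scatter) in this assay.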

Compound 3, dose for half-maximal effect: 0.8 mg/kg
Estimate against measurement, compound 3: 4.4-fold (0.64 log units) above; the whole stated range lies above it.
By their numbers in this assay, from the lowest: compound 3; then compounds 2 and 1 (each within the scatter of the next).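

This position is not indifferent to the group it carries. In this assay, among these compounds, ethoxy in place of chloro on the aromatic carbon between two ring nitrogen atoms gives a 3.1-fold lower number from compound 2 to compound 3 (0.49 log units; beyond the scatter) and is the first change here to move the number beyond the scatter. On this read-out, the larger group with its hydrogen-bond acceptor brings the effect on at smaller amounts of compound, although nothing measured here says why the number moves.

A single exchange cannot show whether the oxygen or the length of the chain matters, and methoxy, propoxy or an amine such as dimethylamino on the same carbon would help separate the two. As far as these compounds go, it also remains open whether ethoxy would give a similar step with other groups elsewhere on the shared core.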